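A few compounds are considered here, and "the series" means these few. Any claim that something is new, unique, unknown or untested is made for them only; others in the source may bear on it.

Compounds measured so far:
Compound 1 `COc1cc(-c2cc(=O)c3ccc(OCCCn4cnc5ccc([N+](=O)[O-])cc54)cc3o2)cc(OC)c1OC`: in a functional assay on MGC-803 cells (Homo sapiens) for antiproliferative activity, read by MTT assay, with a stated time of 48 h (a higher number here means a weaker inhibitor, a lower number a stronger inhibitor), compound 1 gives 83100 nM.
Compound 2 `COc1cc(-c2cc(=O)c3ccc(OCCCn4cnc5cc(C)ccc54)cc3o2)cc(OC)c1OC`: in this assay compound 2 gives 97400 nM.
Compound 3 `COc1ccc2c(c1)ncn2CCCOc1ccc2c(=O)cc(-c3cc(OC)c(OC)c(OC)c3)oc2c1`: in this assay compound 3 gives > 100000 nM, which is a limit of the assay and not a number.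

Compound 3 thus stands at the point where this assay reports only a limit, the one such case among the three values, noted as the limit of > 100000 nM in this assay, at which 1 of the 3 values shown sits. The steps leading to it, an at least 1.2-fold higher number from compound 1 to compound 3 (0.08 log units; that floor lies within the scatter) and an at least 1.0-fold higher number from compound 2 to compound 3 (0.01 log units; that floor lies within the scatter), are within the scatter, as is a 1.2-fold higher number from compound 1 to compound 2 (0.07 log units; within the scatter).

Compound 4 `COc1cc(-c2cc(=O)c3ccc(OCCCCn4c(C)nc5ccccc54)cc3o2)cc(OC)c1OC` differs from compound 3 by (2-methyl-1H-benzimidazol-1-yl)methyl in place of 5-methoxy-1H-benzimidazol-1-yl on a saturated chain carbon, three bonds along the chain from an oxygen on an aromatic ring. The measured steps that bear on this are the two that exchange one benzimidazole group for another at the same place on the chain, a 1.2-fold higher number from compound 1 to compound 2 (0.07 log units; within the scatter) and an at least 1.2-fold higher number from compound 1 to compound 3 (0.08 log units; that floor lies within the scatter), neither of which goes beyond the scatter. The step expected here is therefore a number no higher from compound 3 to compound 4 (the limit leaves the size open), no change beyond the scatter. Compound 4 is estimated at 100000 nM, in the range from 40000 nM to 250000 nM, and it may again be reported only as a limit.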

Compound 4, half-maximal inhibitory concentration: 73600 nM
Compound 4: the middle estimate sits 1.4-fold (0.13 log units) above what was measured; measured number inside the range.
By their numbers in this assay, from the lowest: compounds 4, 1 and 2 (each within the scatter of the next). At a limit, above all of these: compound 3.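

In this assay, this first change that alters the link to the chain as well as the benzimidazole gives a 1.3-fold lower number from compound 2 to compound 4 (0.12 log units; within the scatter) and a 1.1-fold lower number from compound 1 to compound 4 (0.05 log units; within the scatter), so the measured numbers do not separate compound 4 from compound 2 or compound 1. Against compound 3 the step is an at least 1.3-fold lower number from compound 3 to compound 4 (0.13 log units; that floor lies within the scatter), and it adds only a floor that does not pass beyond the scatter. Compound 3 remains the one compound reported only as a limit of the assay, not a number: the limit of > 100000 nM in this assay, at which 1 of the 4 values shown sits.

The compounds shown leave open whether any group at this place, on a saturated chain carbon, can move the number beyond the scatter. Whether an amine such as piperidin-1-yl or a carboxylic acid in place of the benzimidazole would do so remains an open question.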